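A few compounds are considered here, and "the series" means these few. Any claim that something is new, unique, unknown or untested is made for them only; others in the source may bear on it.

In an ADME assay on MT4 cells (Homo sapiens) for cytotoxicity, read by MTT assay, with a stated time of 5 days (a lower number here means that less compound is tolerated, a higher number that more compound is tolerated), compound 1 `Cc1cccc(Cn2cc(CNC(=O)c3cnc(Nc4ccc(C#N)cc4)cc3Oc3c(C)cc(C)cc3C)nn2)c1` gives 114000 nM, the highest of the two plain numbers shown. Compound 3 `Cc1cc(C)c(Oc2cc(Nc3ccc(C#N)cc3)ncc2C(=O)NCc2cn(CCCO)nn2)c(C)c1` gives 25200 nM in this assay, and the step between them is a 4.5-fold lower number from compound 1 to compound 3 (0.66 log units; beyond the scatter). Compound 2 `Cc1cc(C)c(Oc2cc(Nc3ccc(C#N)cc3)ncc2C(=O)NCc2cn(Cc3ccccc3C#N)nn2)c(C)c1` reaches only a limit of this assay, > 219000 nM. That is the limit of > 219000 nM in this assay, at which 1 of the 3 values shown sits. The remaining measured steps are an at least 1.9-fold higher number from compound 1 to compound 2 (0.28 log units; that floor lies within the scatter) and an at least 8.6-fold lower number from compound 2 to compound 3 (0.93 log units; beyond the scatter).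

Compound 4 `Cc1cc(C)c(Oc2cc(Nc3ccc(C#N)cc3)ncc2C(=O)NCc2cn(CC(=O)N3CCCC3)nn2)c(C)c1` has not been measured in this assay. Its difference from compound 1 is (pyrrolidin-1-yl)carbonyl in place of 3-methylphenyl on a saturated chain carbon bound to an aromatic nitrogen. Among the measured steps, the one that bears most closely on it is the replacement of the 3-methylphenyl by 2-hydroxyethyl, a 4.5-fold lower number from compound 1 to compound 3 (0.66 log units; beyond the scatter), since both changes remove the same aromatic group from the saturated chain carbon bound to the aromatic nitrogen. A lowering of the number for compound 4 is therefore expected, though a smaller one than that seen for compound 3, given the uncertainty of a single comparison. Compound 4 is expected to give about 60000 nM in this assay, within a range from 20000 nM to 180000 nM. That estimate corresponds to an expected step of a 1.9-fold lower number from compound 1 to compound 4 (0.28 log units; within the scatter).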

Compound 4, half-maximal cytotoxic concentration: 58100 nM
The estimate for compound 4 lay 1.0-fold (0.01 log units) above the measured number; the measured number falls inside the stated range.
By their numbers in this assay, from the lowest: compound 3; then compounds 4 and 1 (each within the scatter of the next). At a limit, above all of these: compound 2.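

In this assay, compound 4 shows that the 3-methylphenyl can leave this saturated chain carbon without a step beyond the scatter, a 2.0-fold lower number from compound 1 to compound 4 (0.29 log units; within the scatter), so losing that aromatic ring does not by itself bring the number down to that of compound 3. The two groups without an aromatic ring also separate at this place, since (pyrrolidin-1-yl)carbonyl in place of 2-hydroxyethyl gives a 2.3-fold higher number from compound 3 to compound 4 (0.36 log units; beyond the scatter). Compound 2 gives only a limit, so the step to the 2-cyanophenyl compound, an at least 3.7-fold lower number from compound 2 to compound 4 (0.57 log units; beyond the scatter), is a floor and not a measured size: the limit of > 219000 nM in this assay, at which 1 of the 4 values shown sits.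

As far as these compounds go, it remains open whether an amine or a carboxylic acid at this place would stay close to compound 4 or fall towards compound 3. The same holds for a longer chain before the carbonyl, or for a piperidine ring in place of the pyrrolidine.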